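Fluoro in place of hydrogen on the pendant phenyl

This account rests on a few compounds, and the source may have more. Where it says the series, first, only, none or still open, it means among the compounds named here.

Compound 1 `COc1cc2c(Oc3ccc(NC(=O)c4cc(-c5ccccc5)ccn4)cc3F)ccnc2cc1OCCCN1CCN(C)CC1` holds the lower of the two numbers in hand. In a functional assay on HT-29 cells (Homo sapiens) for cytotoxicity, read by MTT assay, with a stated time of 72 h (on this read-out higher numbers stand for weaker inhibition and lower numbers for stronger inhibition), compound 1 gives 82 nM. The other measured member, compound 2 `COc1cc2c(Oc3ccc(NC(=O)c4cc(-c5ccccc5F)ccn4)cc3F)ccnc2cc1OCCCN1CCCCC1`, in this assay gives 320 nM; the two values show compound 2 sitting higher, beyond the scatter, and nothing more can be drawn from that pair. Compound 3 `COc1cc2c(Oc3ccc(NC(=O)c4cc(-c5ccc(F)cc5)ccn4)cc3F)ccnc2cc1OCCCN1CCN(C)CC1` arises from compound 1 by one change: fluoro in place of hydrogen on an aromatic carbon, read one bond further out as phenyl to 4-fluorophenyl. Among the compounds with values here, no matched step of this kind exists among the measured compounds, so the expectation rests on the smallness of the change alone. The expected step of a 1.1-fold higher number from compound 1 to compound 3 (0.04 log units; within the scatter) is none beyond the scatter, in either direction. Compound 3 is estimated at 90 nM, with a range from 40 nM to 200 nM.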

Compound 3, half-maximal inhibitory concentration: 1460 nM
Beside the measured number, compound 3's estimate is 16-fold (1.21 log units) below it, outside the stated range (above it).
By their numbers in this assay, from the lowest: compound 1; then compound 2; then compound 3.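

In this assay, the phenyl of the shared core is sensitive at this carbon: fluoro in place of hydrogen, para to a large group, adds a single heavy atom and still gives an 18-fold higher number from compound 1 to compound 3 (1.25 log units; beyond the scatter). The size of a change therefore does not predict its effect at this position, and this one replacement separates two compounds otherwise identical. Nothing at hand explains the weaker number in this cell read-out.

On these data alone, whether the step is tied to fluoro or to any group on that carbon stays open, and chloro, methoxy or an amine at the same place would separate the two. Also open, as far as these compounds go, is whether the step keeps its size with a longer chain in place of the side chain of compound 1.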